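This account rests on a few compounds, and the source may have more. Where it says the series, first, only, none or still open, it means among the compounds named here.

Working notes on the series. Going by the values given here, in an assay on HEK293 cells for displacement of a labelled ligand from adenosine receptor A2b (Homo sapiens), read by radioligand binding, with a stated time of 30 min (a lower number here means a stronger inhibitor, a higher number a weaker inhibitor), compound 2 `CCOC(=O)C1=C(C(F)(F)F)NC(=O)NC1c1ccsc1` gives 575 nM, the second highest of the three numbers so far; compound 1 `CC(C)OC(=O)C1=C(C(F)(F)F)NC(=O)NC1c1ccsc1` gives 651 nM, a step of a 1.1-fold lower number from compound 1 to compound 2 (0.05 log units; within the scatter) lying within the scatter, and compound 3 `CC(C)OC(=O)C1=C(C(F)(F)F)NC(=O)NC1c1ccco1` gives 238 nM. Compound 4 `CCOC(=O)C1=C(C(F)(F)F)NC(=O)NC1c1ccoc1` is the next target; the change from compound 2 is furan-3-yl in place of thiophen-3-yl on a saturated ring carbon. Among the compounds with values here, the one measured step that bears on it is a 2.7-fold lower number from compound 1 to compound 3 (0.44 log units; beyond the scatter), though that step exchanged thiophen-3-yl for furan-2-yl rather than furan-3-yl. On that basis a modest fall in this assay is expected for compound 4, about a 2.1-fold lower number from compound 2 to compound 4 (0.31 log units; beyond the scatter), with the isomer difference widening the range. Compound 4 is estimated at 280 nM, range 120 nM to 650 nM.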

Compound 4, inhibition constant: 521 nM
Compound 4: middle estimate off by 1.9-fold (0.27 log units), on the low side; the range from low to high includes it.
By their numbers in this assay, from the lowest: compound 3; then compounds 4, 2 and 1 (each within the scatter of the next).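

In this assay, the exchange of thiophen-3-yl for furan-3-yl on the saturated ring carbon gives a 1.1-fold lower number from compound 2 to compound 4 (0.04 log units; within the scatter), so replacing the ring sulfur with oxygen at this attachment has no effect that can be read. A furan ring alone therefore does not reproduce a 2.7-fold lower number from compound 1 to compound 3 (0.44 log units; beyond the scatter), which brought in furan-2-yl on a different ester. No measurement here accounts for this result.

Still open, going by these compounds, is whether furan-2-yl with the ethoxycarbonyl group matches that earlier step. Also open, on these data alone, is how a phenyl ring or an aminomethyl-substituted furan would behave on this carbon.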